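Halophenyl thiosemicarbazones on the cyclohexenyl core

A few compounds are considered here, and "the series" means these few. Any claim that something is new, unique, unknown or untested is made for them only; others in the source may bear on it.

Compound 1 `CC1=CC[C@H](C(C)(C)NC(=S)N/N=C/c2ccccc2O)CC1` carries a 2-hydroxyphenyl on the carbon with a double bond to nitrogen, and in a functional assay on NCI/ADR-RES cells (Homo sapiens) for inhibition, read by sulforhodamine B assay, with a stated time of 48 h (on this read-out higher numbers stand for weaker inhibition of growth and lower numbers for stronger inhibition of growth), compound 1 gives 3700 nM. Compound 2 `CC1=CC[C@H](C(C)(C)NC(=S)N/N=C/c2ccc(F)cc2)CC1` replaces this group with 4-fluorophenyl. In this assay compound 2 reaches only the limit of the assay, > 100000 nM, so no number is known for it. The step of an at least 27-fold higher number from compound 1 to compound 2 (1.43 log units; beyond the scatter) is therefore a lower bound on the loss, set by the limit of > 100000 nM in this assay, at which 1 of the 2 values shown sits. Compound 3 `CC1=CC[C@H](C(C)(C)NC(=S)N/N=C/c2cccc(Cl)c2)CC1` is the next variant: 3-chlorophenyl in place of 4-fluorophenyl on a carbon with a double bond to nitrogen. Among the measured compounds shown here, no measured step bears directly on an exchange of one halophenyl for another; the only step available, an at least 27-fold higher number from compound 1 to compound 2 (1.43 log units; beyond the scatter), concerns the removal of the 2-hydroxyphenyl and does not compare halophenyls with each other. Since compound 2 stands at a limit, no step size can be computed from it in either direction. The expectation for compound 3 is a weak inhibitor, with a value estimated at 80000 nM (15000 nM to 300000 nM) in this assay, which means an expected step of an at least 1.2-fold lower number from compound 2 to compound 3 (0.09 log units; that floor lies within the scatter) and a real chance that the assay again reports only a limit.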

Compound 3, concentration for 50% growth inhibition: 67500 nM
Compound 3: middle estimate off by 1.2-fold (0.07 log units), on the high side; measured number inside the range.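

Compound 3 gives this position a halophenyl with a real number in this assay, so leaving the 2-hydroxyphenyl now has a measured size and not only a bound: an 18-fold higher number from compound 1 to compound 3 (1.26 log units; beyond the scatter). Both halophenyl compounds shown therefore lie on the weak side of compound 1, and no compound shown goes against this, though the series holds only these two halophenyls. The exchange of 4-fluorophenyl for 3-chlorophenyl gives an at least 1.4-fold lower number from compound 2 to compound 3 (0.17 log units; that floor lies within the scatter), which does not order the two halophenyls, and this step stays a floor because compound 2 stands at a limit: the limit of > 100000 nM in this assay, at which 1 of the 3 values shown sits.

The names 4-fluorophenyl and 3-chlorophenyl differ in both the halogen and the number of its place, so the compounds shown do not separate these two changes. Also open, on these data alone, is whether the hydroxyl itself accounts for the stronger inhibition of growth by compound 1, a question that a phenyl bearing a methoxy group or an amine in its place on the carbon with a double bond to nitrogen would address.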